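Cinnamoyl hydrazides on a shared core: the bromo analogue

The source may report more compounds than this note shows. Statements on the series, on what has been measured and on what is new or still open speak of the compounds shown alone.

Working notes on a small set of hydrazides built on one shared core, the core of compound 1 `Cc1ccccc1/C=C/C(=O)NNC(=O)c1ccc2c(c1)OCCO2`, tested in a functional assay on cells (Cancer cell lines, Homo sapiens) for inhibition, read by MTT assay, with a stated time of 48 h; on this read-out lower numbers stand for stronger inhibition and higher numbers for weaker inhibition. Within the data shown here, compound 1 gives 7710 nM, the highest of the three numbers measured so far. Among the measured compounds shown here, compound 2 `O=C(/C=C/c1ccccc1Cl)NNC(=O)c1ccc2c(c1)OCCO2` gives 4880 nM, and the step of a 1.6-fold lower number from compound 1 to compound 2 (0.20 log units; within the scatter) is the one change on an aromatic carbon in the set. Compound 3 `O=C(/C=C/c1cccc(Cl)c1)NNC(=O)c1ccc2c(c1)OCCO2` gives 3560 nM; the step of a 2.2-fold lower number from compound 1 to compound 3 (0.34 log units; beyond the scatter) is the only one that clears the scatter, while a 1.4-fold lower number from compound 2 to compound 3 (0.14 log units; within the scatter) does not.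

Compound 4 `O=C(/C=C/c1cccc(Br)c1)NNC(=O)c1ccc2c(c1)OCCO2` has not been measured. Against compound 1 the change is 3-bromophenyl in place of 2-methylphenyl on a double-bonded chain carbon bound to a double-bonded chain carbon. For the measured compounds named here, the closest precedent is the step of a 2.2-fold lower number from compound 1 to compound 3 (0.34 log units; beyond the scatter), where a halogen at the same place on the phenyl replaced the 2-methylphenyl; that step was modest, and nothing measured here separates bromine from chlorine. A modest step of similar size is therefore expected in this assay, toward a lower number, and the step of a 2.3-fold lower number from compound 1 to compound 4 (0.37 log units; beyond the scatter) is the estimate. Compound 4 is expected to give about 3300 nM, with a range from 1600 nM to 7000 nM.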

Compound 4, half-maximal inhibitory concentration: 3330 nM
For compound 4 the middle estimate is 1.0-fold (0.00 log units) below the measured one, and the stated range covers the measured number.
By their numbers in this assay, from the lowest: compounds 4, 3, 2 and 1 (each within the scatter of the next, the first and the last beyond it).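

Bromo in place of chloro on this aromatic carbon makes no difference that can be read, with a 1.1-fold lower number from compound 3 to compound 4 (0.03 log units; within the scatter), so bromine and chlorine cannot be told apart here. The 3-bromophenyl and the 2-chlorophenyl are not separated either, with a 1.5-fold lower number from compound 2 to compound 4 (0.17 log units; within the scatter), while a 2.3-fold lower number from compound 1 to compound 4 (0.36 log units; beyond the scatter) gives a second halogen-bearing phenyl, after compound 3, whose step from the 2-methylphenyl clears the scatter. Nothing measured here accounts for these steps.

The compounds shown leave open whether any group on this phenyl moves the number much further than these small steps, since only methyl, chloro and bromo appear. Going by these compounds, an amine, a carboxylic acid or a methoxy group on the phenyl remains open, as does a longer chain in place of the double-bonded chain carbons.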